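Taking the hydroxy off compound 2

A few compounds are considered here, and "the series" means these few. Any claim that something is new, unique, unknown or untested is made for them only; others in the source may bear on it.

In an ADME assay on cells (Homo sapiens) for antiproliferative activity, read by MTT assay (on this read-out lower numbers stand for stronger inhibition and higher numbers for weaker inhibition), compound 1 (`O=C(N/N=C/c1ccccn1)c1cccc(Br)c1`) gives 13500 nM and compound 2 (`C/C(=N\NC(=O)c1ccc(O)cc1)c1cnccn1`) gives 16800 nM while compound 3 (`O=C(NN=C(c1ccccn1)c1ccccn1)c1ccc(O)cc1`) gives 7530 nM as the third reference point. Compound 2 therefore sits at the upper end of these numbers, level with compound 1 within the scatter, while compound 3 lies lower by more than the scatter.

The next compound to be read is compound 4 (`C/C(=N\NC(=O)c1ccccc1)c1cnccn1`). Its change from compound 2 is hydrogen in place of hydroxy on an aromatic carbon (in words, hydrogen in place of hydroxy on an aromatic carbon). Among the measured compounds shown here, no two measured compounds differ in one place only, so the data hold no direct guide to this change in this assay and the expectation has to stay broad. The measured numbers run only from compound 3 at 7530 nM to compound 2 at 16800 nM across three different structures. On that basis, no shift beyond the scatter is expected in either direction. The expected size is a 1.1-fold lower number from compound 2 to compound 4 (0.05 log units; within the scatter) as the estimate stands, a step within the scatter. Compound 4 is estimated at 15000 nM with 6500 nM and 35000 nM as the expected ends of the range.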

Compound 4, half-maximal inhibitory concentration: 3620 nM
Beside the measured number, compound 4's estimate is 4.1-fold (0.62 log units) above it, and the stated range ends above it.
By their numbers in this assay, from the lowest: compound 4; then compounds 3, 1 and 2 (each within the scatter of the next, the first and the last beyond it).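

In this assay, among the compounds shown here, this is the first pair that differs in one place, and it gives a 4.6-fold lower number from compound 2 to compound 4 (0.67 log units; beyond the scatter). The hydroxy on the aromatic carbon, para to a large group, is therefore not interchangeable with hydrogen here: hydrogen in its place goes with a step beyond the scatter toward stronger inhibition, the reverse of no shift at all at this position. This reading rests on one pair with one core, and no measurement at hand accounts for the step, so it stands as an observed difference without an established cause.

Still open, as far as these compounds go, is how other groups at this place would read against hydrogen and hydroxy, for example methoxy, an amine, fluorine or a carboxylic acid, and whether any of them would keep the lower number of compound 4 or return toward that of compound 2. Also open is whether hydrogen in place of hydroxy gives a step of similar size on the core of compound 3, which carries the same hydroxy but has no partner without it among the compounds shown here.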